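The source may report more compounds than this note shows. Statements on the series, on what has been measured and on what is new or still open speak of the compounds shown alone.

Measured compounds:
compound 1 `CCCCC#Cc1cncc(OC[C@@H]2CCCN2C)c1`: 21 nM
compound 2 `CN1CCC[C@H]1COc1cncc(C#CCO)c1`: 7.1 nM
compound 3 `CN1CCC[C@H]1COc1cncc(C#CCCCCO)c1`: 13 nM

In an assay on a protein complex for binding affinity to Neuronal acetylcholine receptor; alpha3/beta2 (Homo sapiens) (on this read-out lower numbers stand for stronger inhibition and higher numbers for weaker inhibition), compound 3 stands second highest of the three numbers; its nearest neighbour is compound 1 and its furthest compound 2, both within the scatter. Compound 4 `CN1CCC[C@H]1COc1cncc(C#Cc2ccccc2)c1` differs from compound 3 by phenyl in place of 4-hydroxybutyl on a triple-bonded carbon. Among the compounds with values here, the steps that bear on this place are a 3.0-fold lower number from compound 1 to compound 2 (0.47 log units; beyond the scatter) and a 1.8-fold higher number from compound 2 to compound 3 (0.26 log units; within the scatter), together with a 1.6-fold lower number from compound 1 to compound 3 (0.21 log units; within the scatter): the chains carrying a hydroxy group gave lower numbers than the plain propyl chain of compound 1, and no measured step introduces an aromatic ring at this position. Compound 4 is therefore expected to give a somewhat higher number, a 2.3-fold higher number from compound 3 to compound 4 (0.36 log units; beyond the scatter), estimated at 30 nM with a range of 8 nM to 120 nM.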

Compound 4, inhibition constant: 8.6 nM
Beside the measured number, compound 4's estimate is 3.5-fold (0.54 log units) above it; the range from low to high includes it.
By their numbers in this assay, from the lowest: compounds 2, 4, 3 and 1 (each within the scatter of the next, the first and the last beyond it).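

In this assay, phenyl on the triple-bonded carbon matches the hydroxy chains, with a 1.5-fold lower number from compound 3 to compound 4 (0.18 log units; within the scatter) and a 1.2-fold higher number from compound 2 to compound 4 (0.08 log units; within the scatter) as its steps. Set against butyl, phenyl gives a 2.4-fold lower number from compound 1 to compound 4 (0.39 log units; beyond the scatter) as its step, so in this series a low number at this position does not depend on a hydroxy group. No measurement here explains these numbers. Still open, on these data alone, is whether phenyl carrying a methoxy group or a fluorine keeps this level, and whether an amine or a carboxylic acid at the end of a chain does the same.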